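The source may report more compounds than this note shows. Statements on the series, on what has been measured and on what is new or still open speak of the compounds shown alone.

Going by the values given here, in a functional assay on MCF7 cells (Homo sapiens) for inhibition, read by MTT assay, with a stated time of 72 h (on this read-out higher numbers stand for weaker inhibition and lower numbers for stronger inhibition), compound 3 (`CNC(=O)CCCCCCCn1nc(-c2ccc3oc(N)nc3c2)c2c(N)ncnc21`) gives 7220 nM, the lowest of the three numbers so far. Compound 1 (`Nc1ncnc2c1c(-c1cnc3[nH]ccc3c1)nn2CCCCCCC(=O)NO`) stands at 19800 nM and compound 2 (`Nc1nc2cc(-c3nn(CCCCCCCCC(=O)NO)c4ncnc(N)c34)ccc2o1`) at 42100 nM, both beyond the scatter from compound 3.

The next compound is compound 4 (`Nc1nc2cc(-c3nn(CCCCCCC(=O)NO)c4ncnc(N)c34)ccc2o1`), which has hydroxycarbamoyl in place of (methylcarbamoyl)methyl on a saturated chain carbon, six bonds along the chain from an aromatic nitrogen.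

Among the compounds with values here, one measured step bears on this change: a 5.8-fold lower number from compound 2 to compound 3 (0.77 log units; beyond the scatter). It exchanges the same two kinds of chain end in the opposite sense, with methylcarbamoyl in place of (hydroxycarbamoyl)methyl, seven bonds along the chain from an aromatic nitrogen. Read backwards, it points to a higher number on going to compound 4, of modest size. Within the data shown here, the data hold only this single step, so its transfer to a different chain position is untested. Among the measured compounds shown here, compound 1 at 19800 nM gives a second reference level, though no single-place step connects it to the other compounds.

The estimated step is a 2.8-fold higher number from compound 3 to compound 4 (0.44 log units; beyond the scatter), a modest rise that is expected to be somewhat smaller than the measured one. For compound 4 the expected value in this assay is 20000 nM, with an estimated range of 7000 nM to 50000 nM.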

Compound 4, half-maximal inhibitory concentration: 11900 nM
Compound 4: middle estimate off by 1.7-fold (0.23 log units), on the high side; the range from low to high includes it.
By their numbers in this assay, from the lowest: compounds 3, 4 and 1 (each within the scatter of the next, the first and the last beyond it); then compound 2.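

In this assay, a 1.6-fold higher number from compound 3 to compound 4 (0.22 log units; within the scatter) stays within the scatter, so with the core of compound 3 kept, hydroxycarbamoyl in place of (methylcarbamoyl)methyl at this position does not separate the two compounds. Going by these compounds alone, the chain end alone gives a clearer difference: a 3.5-fold lower number from compound 2 to compound 4 (0.55 log units; beyond the scatter) is beyond the scatter, with hydroxycarbamoyl in place of 2-(hydroxycarbamoyl)ethyl, and this is the first step in which both compounds carry the hydroxycarbamoyl end, so the difference between these two compounds lies in how far along the chain it sits. The aromatic group on the core makes no clear difference on this chain, as a 1.7-fold lower number from compound 1 to compound 4 (0.22 log units; within the scatter) also stays within the scatter.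

Open, going by these compounds, is whether a carboxylic acid or a primary amine at the chain end would keep the number near those of compound 3 and compound 4, and whether the group carried by compound 1 would follow the same course on the longer chain of compound 2. No measurement at hand speaks to what lies behind any of these steps.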